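Swapping the furan for a cyanophenyl on the pyrazoline

A few compounds are considered here, and "the series" means these few. Any claim that something is new, unique, unknown or untested is made for them only; others in the source may bear on it.

Measured so far:
compound 1, `CC(=O)N1N=C(c2cc(O)c(O)c([N+](=O)[O-])c2)CC1c1ccco1`, 77400 nM
compound 2, `N#Cc1cccc(/C=C/C(=O)c2cc(O)c(O)c([N+](=O)[O-])c2)c1`, 60600 nM
compound 3, `Cn1cc(/C=C/C(=O)c2cc(O)c(O)c([N+](=O)[O-])c2)cn1`, 66200 nM

All three compounds were tested in an assay on isolated protein for inhibition of Amine oxidase [flavin-containing] B (Homo sapiens), read by fluorescence; on this read-out higher numbers stand for weaker inhibition and lower numbers for stronger inhibition. Compound 1 gives 77400 nM there, and its number lies within the scatter of both compound 3 at 66200 nM and compound 2 at 60600 nM, so no order can be read among the three; compound 1 is simply one of three weak, closely grouped values.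

Compound 4, `CC(=O)N1N=C(c2cc(O)c(O)c([N+](=O)[O-])c2)CC1c1cccc(C#N)c1`, has not yet been measured. It differs from compound 1 in one place: 3-cyanophenyl in place of furan-2-yl on a saturated ring carbon. Compound 2 already carries a 3-cyanophenyl group, though on a different part of its structure, and its value sits within the scatter of compound 1, which gives no sign that this group by itself moves the read-out far. Among the measured compounds shown here, no pair of measured compounds differing only in this way exists, so the size of the step is unknown.

The expectation is therefore that the step from compound 1 to compound 4 in this assay stays within the scatter, a 1.2-fold lower number from compound 1 to compound 4 (0.08 log units; within the scatter), with no clear direction. For compound 4 the estimated value is 65000 nM, with a range from 30000 nM to 140000 nM.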

Compound 4, half-maximal inhibitory concentration: 55400 nM
The estimate for compound 4 lay 1.2-fold (0.07 log units) above the measured number, and the stated range covers the measured number.
By their numbers in this assay, from the lowest: compounds 4, 2, 3 and 1 (each within the scatter of the next).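

In this assay, among the compounds shown here, 3-cyanophenyl in place of furan-2-yl on the saturated ring carbon gives a 1.4-fold lower number from compound 1 to compound 4 (0.15 log units; within the scatter) and so provides the direct reading at this position that the earlier compounds could not offer. With the rest of the core of compound 1 unchanged, a five-membered aromatic ring with one hetero atom and a six-membered aromatic ring of carbon only, bearing a nitrile, cannot be told apart on this read-out, even though the entering group is the larger by heavy-atom count. The data offer no explanation for the size of this step.

The compounds shown leave open whether any group on this saturated ring carbon can shift the number beyond the scatter, for example a phenyl ring carrying an amine or a carboxylic acid, or a longer alkyl chain in place of the aromatic ring. They also leave open what the acetyl group on the ring nitrogen contributes, a question that a longer acyl chain there could address.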